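Expected Acid Dissociation After a Swap on the Aromatic Core

The source may report more compounds than this note shows. Statements on the series, on what has been measured and on what is new or still open speak of the compounds shown alone.

Compound 1 `Fc1ccc(-c2ccc3c(NCCCNCc4ccco4)ccnc3c2)cc1` and compound 2 `COc1ccc(F)cc1CNCCCNc1ccnc2cc(-c3ccc(F)cc3)ccc12` share a core that carries a saturated chain ending in an amine nitrogen; they differ only in the group on the chain carbon bound to that nitrogen. In a physicochemical assay for acid dissociation, compound 1 gives 9.47, and compound 2 gives 9.47. The step of no change at the digits printed from compound 1 to compound 2 (within the scatter) shows that putting 5-fluoro-2-methoxyphenyl in place of furan-2-yl there leaves the read-out where it was, so compound 1 stands level with compound 2 on the numbers available.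

Compound 3 `COc1ccccc1Oc1ccc2c(NCCCNCc3ccco3)ccnc2c1` has not been measured. It differs from compound 1 in 2-methoxyphenoxy in place of 4-fluorophenyl on an aromatic carbon. For the measured compounds named here, no measured step touches this place on the fused ring system, so the single step from compound 1 to compound 2 bears on it only indirectly: it shows that a change away from the chain nitrogen left the value flat, and the change in compound 3 lies on the aromatic core, not on the chain. I therefore expect no step beyond the scatter, and the expected step of a number 0.02 log units lower from compound 1 to compound 3 (within the scatter) reflects that. For compound 3 the estimated value in this assay is 9.45, with a range from 9.1 to 9.8.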

Compound 3, acid dissociation constant: 9.28
Estimate against measurement, compound 3: 0.17 log units above, within the range that was stated.
By their numbers in this assay, from the lowest: compounds 3, 1 and 2 (each within the scatter of the next).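

In this assay, for the compounds shown here, putting 2-methoxyphenoxy in place of 4-fluorophenyl on an aromatic carbon gives a number 0.19 log units lower from compound 1 to compound 3 (within the scatter), the first reading for a change on the shared core rather than on the chain. The swap is not a small one on paper: the leaving group has 7 heavy atoms and 0 hydrogen-bond acceptors, the entering group 9 and 2, yet the step stays within the scatter, so at this position this change leaves the read-out indistinguishable from that of the 4-fluorophenyl compound. No measurement offered here accounts for that outcome.

Going by these compounds, both groups seen at this position contain a six-membered aromatic ring of carbon only, so it remains open whether a group without such a ring, such as an amine or a carboxylic acid, would give a step beyond the scatter. On these data alone, it also remains open whether 2-methoxyphenoxy on the core would give the same reading when paired with 5-fluoro-2-methoxyphenyl on the chain, or with a longer chain between the core and the amine nitrogen.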